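The compounds below may be only part of what the source reports. "The series", "measured", "known", "first", "only" and "open" are said of these compounds alone.

Measured in a functional assay (trachea) with Cavia porcellus as the target (a higher number here means that more compound is needed for the effect, a lower number that less compound is needed), so far:
compound 1 `CCCn1c(=O)n(CCC(N)=O)c(=O)c2[nH]cnc21` (13100 nM)
compound 2 `CCCn1c(=O)n(CCC#N)c(=O)c2[nH]cnc21` (1700 nM)

Compound 2 (1700 nM) stands lowest of the two measured compounds. Compound 3 `CCCn1c(=O)n(CCN(C)C)c(=O)c2[nH]cnc21` has not yet been measured. It differs from compound 2 by a single change (dimethylamino in place of cyano on a saturated chain carbon, two bonds along the chain from an aromatic nitrogen), dimethylamino in place of cyano on a saturated chain carbon, two bonds along the chain from an aromatic nitrogen. Going by the values given here, only one measured step bears on this change (a 7.7-fold lower number from compound 1 to compound 2 (0.89 log units; beyond the scatter)). It was made on the same chain carbon, it lies beyond the scatter, and it shows that the number responds to a change there. Among the compounds with values here, no measured compound carries dimethylamino, so the evidence is thin. Giving up the cyano of compound 2 (1700 nM) is expected to raise the number by a step of similar, modest size (a 3.5-fold higher number from compound 2 to compound 3 (0.55 log units; beyond the scatter)). Compound 3 is estimated at 6000 nM (expected range 1300 nM to 28000 nM).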

Compound 3, half-maximal effective concentration: 2700 nM
Estimate against measurement, compound 3: 2.2-fold (0.35 log units) above; the measured number falls inside the stated range.
By their numbers in this assay, from the lowest: compounds 2 and 3 (each within the scatter of the next); then compound 1.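

In this assay, putting dimethylamino in place of the nitrile on this chain carbon gives a 1.6-fold higher number from compound 2 to compound 3 (0.20 log units; within the scatter), so the two groups cannot be told apart at this position, despite their different structures. Dimethylamino also gives a 4.9-fold lower number from compound 1 to compound 3 (0.69 log units; beyond the scatter), which shows that the earlier gain over carbamoyl is not unique to the nitrile; among the three compounds, carbamoyl alone stands apart. No measurement at hand accounts for this result.

The compounds shown leave open whether a carboxylic acid, a hydroxyl or a morpholine ring on this chain carbon would group with compound 2 and compound 3 or with compound 1. They also leave open how a longer chain carrying dimethylamino would behave in this assay.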